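The source may report more compounds than this note shows. Statements on the series, on what has been measured and on what is new or still open speak of the compounds shown alone.

Three stereoisomers carry the same amide on a shared core: compound 1 `O=C([C@H]1C[C@H]1F)N1CC2CC(C1)N2`, compound 2 `O=C([C@@H]1C[C@@H]1F)N1CC2CC(C1)N2` and compound 3 `O=C([C@@H]1C[C@H]1F)N1CC2CC(C1)N2`. In an assay on CHO cells for agonist activity at Neuronal acetylcholine receptor; alpha3/alpha6/beta2/beta3 (Homo sapiens), read by FLIPR and calcium flux (on this read-out lower numbers stand for smaller maximal responses and higher numbers for larger maximal responses), compound 1 gives 130%, compound 2 gives 120% and compound 3 gives 130%. The steps among them, a number 10 percentage points lower from compound 1 to compound 2 (within the scatter), no change at the digits printed from compound 1 to compound 3 (within the scatter) and a number 10 percentage points higher from compound 2 to compound 3 (within the scatter), all sit within the scatter, so compound 3 stands level with compound 1 and the three numbers form one group. Compound 4 `C[C@H]1C[C@H]1C(=O)N1CC2CC(C1)N2` differs from compound 3 by 2-methylcyclopropyl in place of 2-fluorocyclopropyl on a carbonyl carbon. Among the compounds with values here, none of the measured steps bears on this change; each of them concerns only a drawn configuration. Within the data shown here, with no step to lean on, the expectation for compound 4 in this assay is placed near the run of the series with a broad range: compound 4 is estimated at 120% (range 90% to 140%), which means an expected step of a number 10 percentage points lower from compound 3 to compound 4 (within the scatter) that is expected to stay within the scatter.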

Compound 4, largest response reached (Emax), in percent of the reference or control that the assay uses: 60%
Compound 4: the middle estimate sits 60 percentage points above what was measured; the measured number lies below the stated range.
By their numbers in this assay, from the lowest: compound 4; then compounds 2, 1 and 3 (each within the scatter of the next).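

In this assay the identity of the group on the cyclopropyl ring, not the drawn configuration, separates these compounds: the result is a number 70 percentage points lower from compound 3 to compound 4 (beyond the scatter) and a number 70 percentage points lower from compound 1 to compound 4 (beyond the scatter), and methyl in place of fluoro on a saturated ring carbon gives a number 60 percentage points lower from compound 2 to compound 4 (beyond the scatter). Among these four compounds, this position accommodates the configurations shown with fluoro retained, but not this exchange for methyl. Nothing available accounts for the drop.

As far as these compounds go, how an unsubstituted cyclopropyl or a 2-chlorocyclopropyl on the same carbonyl carbon would read remains open. So does the response of other stereoisomers of the 2-methylcyclopropyl amide.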